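This account rests on a few compounds, and the source may have more. Where it says the series, first, only, none or still open, it means among the compounds named here.

Compound 1 `CCCCNc1nc(N)nc2c1CN(Cc1ccccc1Cl)CC2` gives 0.05 uM in an assay on HEK293 cells for agonist activity at Toll-like receptor 8 (Homo sapiens), read by a luciferase reporter, with a stated time of 6 h; on this read-out lower numbers stand for an effect already at smaller amounts and higher numbers for an effect only at larger amounts of compound. Compound 2 `CCCCNc1nc(N)nc2c1CN(Cc1cccc(Cl)c1Cl)CC2` gives 0.18 uM.

Compound 1 has the lowest of the two numbers measured in this assay; its nearest neighbour is compound 2, reached by a 3.6-fold higher number from compound 1 to compound 2 (0.56 log units; beyond the scatter), a change that puts chloro in place of hydrogen on an aromatic carbon.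

Compound 3 `CCCCNc1nc(N)nc2c1CN(C(=O)c1cscn1)CC2` has not yet been measured. It differs from compound 1 in one place: (1,3-thiazol-4-yl)carbonyl in place of 2-chlorobenzyl on an amine nitrogen in a ring. Within the data shown here, no measured step bears directly on this change, since the single step that has been measured alters a substituent on the aromatic ring of compound 1 rather than exchanging the whole group on the ring nitrogen. The expectation for compound 3 therefore rests on compound 1 alone and carries wide uncertainty. Compound 3 is expected to give a higher number in this assay, estimated at 0.5 uM, within 0.05 uM to 5 uM. This would correspond to an expected step of a 10-fold higher number from compound 1 to compound 3 (1.00 log units; beyond the scatter).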

Compound 3, minimum effective concentration: 0.5 uM
Beside the measured number, compound 3's estimate shows no gap at the digits printed; low and high end bracket the measured number.
By their numbers in this assay, from the lowest: compound 1; then compound 2; then compound 3.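

In this assay, the amine nitrogen in the ring still gives a reading when the entire 2-chlorobenzyl group is exchanged, not just substituted on its aromatic ring: (1,3-thiazol-4-yl)carbonyl brings a 10-fold higher number from compound 1 to compound 3 (1.00 log units; beyond the scatter) as its step. This single step introduces a carbonyl and also replaces the six-membered aromatic ring of carbon only with a five-membered aromatic ring with 2 hetero atoms, so the two changes cannot be separated. No evidence here accounts for the rise in the number.

Going by these compounds, it remains open how much of the step belongs to the carbonyl and how much to the ring, a question that benzoyl or (1,3-thiazol-4-yl)methyl on the same nitrogen would address. On these data alone, whether a longer chain in place of butyl would shift the number for compound 3 also remains open.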